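The source may report more compounds than this note shows. Statements on the series, on what has been measured and on what is new or still open speak of the compounds shown alone.

Measured in a functional assay on HeLa cells (Homo sapiens) for cytotoxicity, read by MTT assay, with a stated time of 48 h; a lower number here means a stronger inhibitor, a higher number a weaker inhibitor:
compound 1 `Cc1ccc(C)c(/C=C/[C@](C)(O)CC[C@@H]2[C@@]3(C)CCCC(C)(C)[C@@H]3CC[C@@]2(C)O)c1`: 3380 nM
compound 2 `CC1(C)CCC[C@]2(C)[C@@H](CC[C@@](C)(O)/C=C/c3cncc4ccccc34)[C@](C)(O)CC[C@@H]12`: 46000 nM
compound 3 `COc1cccc(/C=C/[C@](C)(O)CC[C@@H]2[C@@]3(C)CCCC(C)(C)[C@@H]3CC[C@@]2(C)O)c1OC`: 3880 nM

Compound 1 shares the low end of these numbers with compound 3, and the two cannot be told apart: a 1.1-fold higher number from compound 1 to compound 3 (0.06 log units; within the scatter). Compound 2 stands well apart: a 14-fold higher number from compound 1 to compound 2 (1.13 log units; beyond the scatter).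

Compound 4 `CC1(C)CCC[C@]2(C)[C@@H](CC[C@@](C)(O)/C=C/c3ccc(Br)cc3)[C@](C)(O)CC[C@@H]12` has not yet been measured. It keeps the core and chain of compound 1 and changes one group: 4-bromophenyl in place of 2,5-dimethylphenyl on a double-bonded chain carbon bound to a double-bonded chain carbon. In words, 4-bromophenyl comes in place of 2,5-dimethylphenyl, and each is one six-membered aromatic ring of carbon only.

The closest guide is the swap of 2,5-dimethylphenyl for 2,3-dimethoxyphenyl, which also keeps a ring of carbon only and gave a 1.1-fold higher number from compound 1 to compound 3 (0.06 log units; within the scatter). The large steps both involve isoquinolin-4-yl, a group compound 4 does not carry; the return step was a 12-fold lower number from compound 2 to compound 3 (1.07 log units; beyond the scatter). Within the data shown here, no measured compound carries bromine, and a single swap is thin evidence, so the range should stay wide. In this assay, no step beyond the scatter is expected, in either direction.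

For compound 4 the estimated value is 4000 nM, with an expected range of 1500 nM to 12000 nM. This estimate means an expected 1.2-fold higher number from compound 1 to compound 4 (0.07 log units; within the scatter).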

Compound 4, half-maximal inhibitory concentration: 45900 nM
Compound 4: middle estimate off by 11-fold (1.06 log units), on the low side; measured number above the stated range.
By their numbers in this assay, from the lowest: compounds 1 and 3 (each within the scatter of the next); then compounds 4 and 2 (each within the scatter of the next).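

In this assay the swap to 4-bromophenyl gives a large step (a 14-fold higher number from compound 1 to compound 4 (1.13 log units; beyond the scatter)), and the step from the other ring of carbon only is also large (a 12-fold higher number from compound 3 to compound 4 (1.07 log units; beyond the scatter)). Until now, only isoquinolin-4-yl had given a large step, but this result shows that a six-membered aromatic ring of carbon only at this place, on a double-bonded chain carbon, does not by itself keep the number low, and that a ring holding nitrogen is not needed for a high one. Compounds 2 and 4 cannot be told apart (a 1.0-fold lower number from compound 2 to compound 4 (0.00 log units; within the scatter)) even though their rings differ, and no measurement offered here explains why these changes matter so much.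

The swap removes two methyl groups and adds one bromine at once, so the compounds shown cannot say whether the bromine, the missing methyl groups or the new arrangement on the ring sets the result. A plain phenyl, 4-chlorophenyl or 4-methylphenyl group at this place would help separate these possibilities.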